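Losing the dichlorophenyl group: from compound 2 to compound 4

The source may hold more compounds than are shown below. What is called first, only, known or untested is meant among the compounds shown, and "the series" means these compounds.

Measured in a functional assay (strain AB) with Danio rerio as the target, read by microscopy, with a stated time of 1 h; a lower number here means that less compound is needed, a higher number that more compound is needed for the effect:
- Compound 1 `CCN1CCc2c(sc(NC(=O)Nc3cccc(Cl)c3Cl)c2C(N)=O)C1`: 17400 nM
- Compound 2 `CCN1CCc2c(sc(NC(=O)NCC3CCCO3)c2C(N)=O)C1`: > 25000 nM (a limit, not a number)
- Compound 3 `CCN1CCc2c(sc(NC(=O)Nc3ccc(Cl)cc3Cl)c2C(N)=O)C1`: 11500 nM

Only a limit is known for compound 2, which sits at the limit of > 25000 nM in this assay, at which 1 of the 3 values shown sits. Compound 4 `CCN1CCc2c(sc(NC(=O)[C@@H]3CCCN3)c2C(N)=O)C1` differs from it in one place: pyrrolidin-2-yl in place of ((oxolan-2-yl)methyl)amino on a carbonyl carbon. In words, pyrrolidin-2-yl stands in place of ((oxolan-2-yl)methyl)amino on a carbonyl carbon.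

For the measured compounds named here, no measured step makes this exact swap, so the evidence is indirect. The closest guide is an at least 2.1-fold lower number from compound 2 to compound 3 (0.33 log units; beyond the scatter), with 2,4-dichlorophenyl in place of (oxolan-2-yl)methyl. The step of an at least 1.4-fold higher number from compound 1 to compound 2 (0.15 log units; that floor lies within the scatter) leans the same way, but it cannot settle the matter alone. Exchanging one dichlorophenyl pattern for the other gives a 1.5-fold lower number from compound 1 to compound 3 (0.18 log units; within the scatter). Among these three compounds, real numbers appear only for the two that carry dichlorophenyl.

Compound 4 has no dichlorophenyl group, so the drop seen in an at least 2.1-fold lower number from compound 2 to compound 3 (0.33 log units; beyond the scatter) is not expected to apply to it. The expected result in this assay is therefore no step beyond the scatter, with an estimated change of a step that the limit leaves unreadable from compound 2 to compound 4. For compound 4 the estimated value is 30000 nM, with an expected range from 12000 nM to 75000 nM.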

Compound 4, half-maximal effective concentration: > 25000 nM
Compound 4: only a limit was reported (the forecaster's own chance of this, stated with the estimate: 70%); the middle value lies beyond the limit too.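

In this assay compound 4 gives > 25000 nM, which is a limit and not a number, the same limit as for compound 2, so no step can be read between the two. The compounds shown leave open whether pyrrolidin-2-yl or ((oxolan-2-yl)methyl)amino on the carbonyl carbon gives the lower number, and how far beyond the limit either compound lies.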